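Sulfonylating the amine of a long-chain threonine amide

The compounds below may be only part of what the source reports. "The series", "measured", "known", "first", "only" and "open" are said of these compounds alone.

Compound 2 `CCCCCCCCCCCCCCCCCCNC(=O)[C@@H](N)[C@@H](C)O` gives 27400 nM in a functional assay on MCF7 cells (Homo sapiens) for cytotoxicity, read by MTT assay, with a stated time of 48 h (a higher number here means a weaker inhibitor, a lower number a stronger inhibitor), the second highest of the three numbers seen. Compound 3 `C/C=C/C=C/C(=O)N[C@H](C(=O)NCCCCCCCCCCCC)[C@@H](C)O` gives 37100 nM, and its difference from compound 2 lies within the scatter, so no order between the two can be read. Within the data shown here, compound 1 `CCCCCCCCCCCCCCNC(=O)[C@@H](N)[C@@H](C)O` gives 10700 nM, and the one measured step, a 2.6-fold higher number from compound 1 to compound 2 (0.41 log units; beyond the scatter), is the only change so far tested, a lengthening of the saturated chain. Compound 4 `CCCCCCCCCCCCCCCCCCNC(=O)[C@@H](NS(=O)(=O)c1cccs1)[C@@H](C)O` differs from compound 2 in one place: (thiophen-2-yl)sulfonyl in place of hydrogen on an amine nitrogen. Among the measured compounds shown here, no measured step touches this nitrogen directly. Compound 3 carries an acyl group on that amine but also a shorter chain, so its value shows only that a capped amine together with a shorter chain sat at the upper end of the measured numbers. On this weak footing a small rise or no change beyond the scatter is expected, estimated as a 1.5-fold higher number from compound 2 to compound 4 (0.16 log units; within the scatter). Compound 4 is therefore expected to give about 40000 nM, within 15000 nM to 110000 nM.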

Compound 4, half-maximal inhibitory concentration: > 200000 nM
Compound 4: a limit, no number (the forecaster's own chance of this, stated with the estimate: 25%); middle value at least 5.0-fold (0.69 log units) from the limit.
By their numbers in this assay, from the lowest: compound 1; then compounds 2 and 3 (each within the scatter of the next). At a limit, above all of these: compound 4.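

Among these compounds, compound 2 and compound 4 give the first one-place comparison at the amine nitrogen, since the only earlier step changed the saturated chain. In this assay, (thiophen-2-yl)sulfonyl in place of hydrogen on this nitrogen gives an at least 7.2-fold higher number from compound 2 to compound 4 (0.86 log units; beyond the scatter), so a free amine is not a neutral feature of this series: replacing its hydrogen with this group clearly weakens the measured effect on the cells. Compound 4 stands at a limit and not at a number, so the full size of this step stays unknown: the limit of > 200000 nM in this assay, at which 1 of the 4 values shown sits.

The compounds shown cannot tell whether the thiophene ring or the sulfonyl link drives this change, which a methanesulfonyl or benzenesulfonyl group on the same nitrogen could help separate. From the compounds shown here alone, it also stays open whether the same change would weigh as heavily on the shorter chain of compound 1.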